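Chain Shortening and a Double Bond in a Biaryl Acid

A few compounds are considered here, and "the series" means these few. Any claim that something is new, unique, unknown or untested is made for them only; others in the source may bear on it.

Compound 1 `O=C(O)CCc1ccccc1-c1cccc(-c2ccccc2OCc2ccccc2)c1` gives 8300 nM in an assay on HEK293 cells for binding affinity to prostaglandin E2 receptor EP1 subtype (Homo sapiens); on this read-out higher numbers stand for weaker inhibition and lower numbers for stronger inhibition.
Compound 2 `O=C(O)CCCc1ccccc1-c1cccc(-c2ccccc2OCc2ccccc2)c1` gives 11900 nM in this assay.
Compound 3 `O=C(O)CCc1ccccc1-c1cc(-c2ccccc2OCc2ccccc2)cs1` gives 17500 nM in this assay.

Among these three, compound 2 stands second highest, but its gaps to compound 1 and to compound 3 both lie within the scatter, so no order among them can be claimed. Compound 4 `O=C(O)/C=C/c1ccccc1-c1cccc(-c2ccccc2OCc2ccccc2)c1` differs from compound 2 by 2-carboxyethenyl in place of 3-carboxypropyl on an aromatic carbon. Among the compounds with values here, the only measured step that changes one place, a 1.4-fold higher number from compound 1 to compound 2 (0.16 log units; within the scatter), lengthened the chain by one carbon and stayed within the scatter. Within the data shown here, no measured step covers the added double bond, so the expectation rests on that small chain effect alone. Compound 4 is therefore expected to give about 9000 nM, with a range from 3000 nM to 30000 nM. The expected step is a 1.3-fold lower number from compound 2 to compound 4 (0.12 log units; within the scatter), nothing beyond the scatter.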

Compound 4, inhibition constant: 72000 nM
Compound 4: the middle estimate sits 8.0-fold (0.90 log units) below what was measured; measured number above the stated range.
By their numbers in this assay, from the lowest: compounds 1, 2 and 3 (each within the scatter of the next, the first and the last beyond it); then compound 4.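

Replacing the saturated chain with 2-carboxyethenyl on this aromatic carbon, ortho to a large group, gives an 8.7-fold higher number from compound 1 to compound 4 (0.94 log units; beyond the scatter) and a 6.1-fold higher number from compound 2 to compound 4 (0.78 log units; beyond the scatter), so binding in this assay is clearly weaker. The first of these steps, from 2-carboxyethyl to 2-carboxyethenyl, adds only the double bond, so this position responds to that change far more than compounds 1 and 2, within the scatter of each other, suggested. Nothing available explains this loss.

Open, on these data alone, is how a triple bond in the chain, or a tetrazole in place of the carboxylic acid, would read here. Also open, as far as these compounds go, is whether 2-carboxyethenyl would give a similar step on the core of compound 3.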